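The source may report more compounds than this note shows. Statements on the series, on what has been measured and on what is new or still open speak of the compounds shown alone.

The series starts from compound 1, `Oc1cccc(-c2cc(-c3ccco3)cc(-c3cccc(O)c3)n2)c1`, which in a functional assay on HeLa cells (Homo sapiens) for cytotoxicity, read by CCK-8 assay (on this read-out higher numbers stand for weaker inhibition and lower numbers for stronger inhibition), gives 5990 nM. Compound 2, `Oc1cccc(-c2cc(-c3ccoc3)cc(-c3ccccc3O)n2)c1`, is known in this assay only as a limit: for compound 2 the assay reports > 50000 nM, and no number is available. On the measurements shown compound 2 therefore stands at the weak end, and of its pair with compound 1 only this much can be said: compound 1 gives a number, compound 2 does not.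

The next compound, compound 3, `Oc1cccc(-c2cc(-c3ccoc3)cc(-c3cccc(O)c3)n2)c1`, differs from compound 2 by a single change: 3-hydroxyphenyl in place of 2-hydroxyphenyl on an aromatic carbon, on an aromatic carbon of the ring with one nitrogen, next to the ring nitrogen. Compound 3 is expected to move toward stronger inhibition in this assay, with a step of an at least 5.0-fold lower number from compound 2 to compound 3 (0.69 log units; beyond the scatter). For compound 3 the estimate in this assay is 10000 nM, with a range from 3000 nM to 50000 nM.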

Compound 3, half-maximal inhibitory concentration: 4630 nM
For compound 3 the middle estimate is 2.2-fold (0.33 log units) above the measured one; the measured number falls inside the stated range.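

At the position next to the ring nitrogen, in this assay, 3-hydroxyphenyl in place of 2-hydroxyphenyl gives an at least 10-fold lower number from compound 2 to compound 3 (1.03 log units; beyond the scatter), so two groups with the same atoms are not interchangeable here. The size of that step is only a lower bound, because compound 2 is known solely by a limit: the limit of > 50000 nM in this assay, at which 1 of the 3 values shown sits. With 3-hydroxyphenyl at this position, the furan change, furan-3-yl in place of furan-2-yl, gives a 1.3-fold lower number from compound 1 to compound 3 (0.11 log units; within the scatter), so the two furan attachments cannot be told apart in this pair.

The compounds shown leave open whether 2-hydroxyphenyl has the same effect alongside furan-2-yl. They also leave open how 4-hydroxyphenyl, 3-methoxyphenyl or an unsubstituted phenyl would fare at this position.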